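Chloro in place of hydrogen: from compound 3 to compound 4

This account rests on a few compounds, and the source may have more. Where it says the series, first, only, none or still open, it means among the compounds named here.

Compound 1, `O=C(Nc1cccc(-n2cc(-c3ccncc3)c(-c3ccc(Cl)c(O)c3)n2)c1)Nc1cccc(C(F)(F)F)c1`, gives in a functional assay on SK-OV-3 cells (Homo sapiens) for inhibition, read by sulforhodamine B assay, with a stated time of 48 h (a higher number here means a weaker inhibitor of growth, a lower number a stronger inhibitor of growth), only a limit, > 32500 nM.
Compound 2, `COc1cc(-c2nn(-c3cccc(NC(=O)Nc4cc(C(F)(F)F)cc(C(F)(F)F)c4)c3)cc2-c2ccncc2)ccc1Cl`, gives in this assay 2570 nM.
Compound 3, `COc1cc(-c2nn(-c3cccc(NC(=O)Nc4cccc(C(F)(F)F)c4)c3)cc2-c2ccncc2)ccc1Cl`, gives in this assay only a limit, > 50000 nM.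

Compound 3 thus sits at the limit of > 50000 nM in this assay, at which 1 of the 3 values shown sits, and compound 1 sits at the limit of > 32500 nM in this assay, at which 1 of the 3 values shown sits; only compound 2 has a real number. The step that the two limits leave unreadable from compound 1 to compound 3 is therefore unreadable. The step of an at least 19-fold higher number from compound 2 to compound 3 (1.28 log units; beyond the scatter) was large: taking a trifluoromethyl off that ring weakened growth inhibition well beyond the scatter. Compound 4, `COc1cc(-c2nn(-c3cccc(NC(=O)Nc4ccc(Cl)c(C(F)(F)F)c4)c3)cc2-c2ccncc2)ccc1Cl`, differs from compound 3 by chloro in place of hydrogen on an aromatic carbon. This again adds a group to the same ring, so a step the other way is expected, though a limit may still result. Compound 4 is expected to give about 8000 nM, between 1500 nM and 50000 nM, an estimated step of an at least 6.2-fold lower number from compound 3 to compound 4 (0.79 log units; beyond the scatter).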

Compound 4, concentration for total growth inhibition: 13000 nM
Compound 4: the middle estimate sits 1.6-fold (0.21 log units) below what was measured; the range from low to high includes it.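

On the ring that carries the trifluoromethyl, chloro ortho to that group gives, in this assay, an at least 3.8-fold lower number from compound 3 to compound 4 (0.58 log units; beyond the scatter). Among the earlier compounds, only a second trifluoromethyl on this ring lowered the number; here a single chlorine atom does so too. The full size of this step cannot be read, since compound 3 has only a limit of the assay: the limit of > 50000 nM in this assay, at which 1 of the 4 values shown sits.

As far as these compounds go, whether a smaller atom such as fluoro, or a group such as an amine or a carboxylic acid, would lower the number at this place remains open. So does whether chloro would have the same effect on the ring of compound 2.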